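Predicting a dichlorophenyl analogue from three measured compounds

The source may report more compounds than this note shows. Statements on the series, on what has been measured and on what is new or still open speak of the compounds shown alone.

A set of three compounds that share one core and differ only in the aryl group on the fused ring system have been measured in an assay for binding affinity to dual specificity mitogen-activated protein kinase kinase 4 (Homo sapiens), read by KINOMEscan, tested at 100 nM; a lower number here means a stronger effect, a higher number a weaker effect of the compound at the concentration tested. Compound 1 `CCCS(=O)(=O)Nc1ccc(F)c(C(=O)c2n[nH]c3ncc(-c4ccccc4Cl)cc23)c1F` gives 9.3%, compound 2 `CCCS(=O)(=O)Nc1ccc(F)c(C(=O)c2n[nH]c3ncc(-c4cccc(Cl)c4)cc23)c1F` gives 40%, and compound 3 `CCCS(=O)(=O)Nc1ccc(F)c(C(=O)c2n[nH]c3ncc(-c4ccc(OC)cc4)cc23)c1F` gives 4.2%. Compound 3 has the lowest of the three numbers; its value and that of compound 1 lie within the scatter of each other, while compound 2 stands well apart, as the step of a number 35.8 percentage points lower from compound 2 to compound 3 (beyond the scatter) shows.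

Compound 4 `CCCS(=O)(=O)Nc1ccc(F)c(C(=O)c2n[nH]c3ncc(-c4cc(Cl)cc(Cl)c4)cc23)c1F` has not been measured. It differs from compound 3 in a single place: 3,5-dichlorophenyl in place of 4-methoxyphenyl on an aromatic carbon

Among the compounds with values here, two measured steps bear on this change. The step of a number 30.7 percentage points higher from compound 1 to compound 2 (beyond the scatter) and the step of a number 35.8 percentage points lower from compound 2 to compound 3 (beyond the scatter) both show that the 3-chlorophenyl analogue carries a much higher number than either the 2-chlorophenyl or the 4-methoxyphenyl analogue. Because compound 2 with 3-chlorophenyl gives 40%, and compound 4 carries chlorine at the 3 position as well, a large upward step is expected for compound 4, of the size a number 40.8 percentage points higher from compound 3 to compound 4 (beyond the scatter). The value of compound 4 in this assay is estimated at 45%, within a range from 15% to 80%.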

Compound 4, a percentage reported as activity, at one concentration (the size of the read-out at that concentration, not a potency): 73%
Compound 4: the middle estimate sits 28 percentage points below what was measured; the range from low to high includes it.
By their numbers in this assay, from the lowest: compounds 3 and 1 (each within the scatter of the next); then compound 2; then compound 4.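

In this assay, chloro in place of hydrogen on the 3-chlorophenyl ring raises the number again, with a number 33 percentage points higher from compound 2 to compound 4 (beyond the scatter), so a second chlorine on this aryl group adds to the loss already seen with one, and compound 4 ends up with the weakest effect of the set. The same change stands out even more against the two low-number analogues, with a number 68.8 percentage points higher from compound 3 to compound 4 (beyond the scatter) and a number 63.7 percentage points higher from compound 1 to compound 4 (beyond the scatter), so this position spans a wider range in this assay than the first three compounds showed, and the 3,5-dichlorophenyl group lies at its high end, while compound 1 shows that a chlorine on this ring does not by itself give a high number. Nothing measured here explains why this substitution carries such a high number.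

The compounds shown leave open whether the rise follows chlorine itself or simply the place it occupies on the ring, which a 3-methoxyphenyl or 3,5-dimethoxyphenyl group would help to separate. They also leave open how a 4-chlorophenyl group, or an amine or a carboxylic acid on this ring, would read in this assay.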